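From methylamino to ethylamino on compound 1

The source may report more compounds than this note shows. Statements on the series, on what has been measured and on what is new or still open speak of the compounds shown alone.

Among the measured compounds shown here, in a functional assay on MV4-11 cells (Homo sapiens) for antiproliferative activity, read by luminescence and CellTiter-Glo, with a stated time of 72 h (on this read-out higher numbers stand for weaker inhibition and lower numbers for stronger inhibition), compound 1 (`CNc1cc(-c2ccc3cnn(Cc4cc(OC)cc(OC)c4)c3c2)cn(C)c1=O`) gives 190 nM and, together with compound 2 (`CNc1cc(-c2ccc3cnn(Cc4ccc(F)c(F)c4)c3c2)cn(C)c1=O`) at 320 nM, sits at the low end of the three numbers measured so far. Compound 3 (`CNc1cc(-c2ccc3cnn(Cc4ccc(C(F)(F)F)cc4)c3c2)cn(C)c1=O`) stands well apart at 4370 nM in the same read-out.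

Compound 4 (`CCNc1cc(-c2ccc3cnn(Cc4cc(OC)cc(OC)c4)c3c2)cn(C)c1=O`) differs from compound 1 in one place (methyl in place of hydrogen on a saturated chain carbon bound to a nitrogen on an aromatic ring): methyl in place of hydrogen on a saturated chain carbon bound to a nitrogen on an aromatic ring, so that methylamino becomes ethylamino.

The measured steps all exchange the phenyl group instead. They are a 1.7-fold higher number from compound 1 to compound 2 (0.23 log units; within the scatter), then a 23-fold higher number from compound 1 to compound 3 (1.36 log units; beyond the scatter) and a 14-fold higher number from compound 2 to compound 3 (1.14 log units; beyond the scatter) as the large ones. None of them touches the methylamino group, so the data give no direct guide to the size or direction of this change. With only one methyl added, a small move towards a higher number is expected, and possibly none beyond the scatter. The expected step is a 1.4-fold higher number from compound 1 to compound 4 (0.14 log units; within the scatter) on this estimate. In this assay compound 4 is estimated at 260 nM within an expected range from 100 nM to 700 nM for a single measurement.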

Compound 4, half-maximal inhibitory concentration: 2590 nM
Estimate against measurement, compound 4: 10-fold (1.00 log units) below, outside the stated range (above it).
By their numbers in this assay, from the lowest: compounds 1 and 2 (each within the scatter of the next); then compounds 4 and 3 (each within the scatter of the next).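

The methylamino group turns out not to be a silent place on the core of compound 1: in this assay, the methyl in place of hydrogen on a saturated chain carbon bound to a nitrogen on an aromatic ring gives a 14-fold higher number from compound 1 to compound 4 (1.13 log units; beyond the scatter). That change enters only one heavy atom, yet its step is marked large and beyond the scatter, as is the exchange of the whole phenyl group in a 23-fold higher number from compound 1 to compound 3 (1.36 log units; beyond the scatter). The earlier compounds varied only the phenyl group and so could not show that this end of the molecule also moves the number; no measurement shown here bears on why this methyl has such an effect.

The compounds shown leave open how the number responds to other groups at this nitrogen, such as a plain amino group, a dimethylamino group or a longer chain such as propyl. They also leave open whether ethylamino in place of methylamino gives a step of similar size when the group on the saturated chain carbon is 3,4-difluorophenyl, as in compound 2, rather than 3,5-dimethoxyphenyl.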